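This account rests on a few compounds, and the source may have more. Where it says the series, first, only, none or still open, it means among the compounds named here.

Measured in a functional assay on MDA-MB-231 cells (Homo sapiens) for antiproliferative activity, read by MTT assay, with a stated time of 24 h; a lower number here means a stronger inhibitor, a higher number a weaker inhibitor:
- compound 1 `Cc1ccccc1NNC(=O)c1ccccc1NS(=O)(=O)c1cnc(O)nc1O`: > 20000 nM (a limit of the assay, not a number)
- compound 2 `O=C(NNc1ccccc1Cl)c1ccccc1NS(=O)(=O)c1cnc(O)nc1O`: 18900 nM
- compound 3 `CCCCOc1ccc(C(=O)NNC(=O)c2ccccc2NS(=O)(=O)c2cnc(O)nc2O)cc1`: 6830 nM

Compound 3 stands lowest at 6830 nM. Its gap to compound 2, which gives 18900 nM, lies beyond the scatter.

Compound 4 `Cc1ccc(C(=O)NNC(=O)c2ccccc2NS(=O)(=O)c2cnc(O)nc2O)cc1` has methyl in place of butoxy on an aromatic carbon.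

For the measured compounds named here, the one measured step, an at least 1.0-fold lower number from compound 1 to compound 2 (0.02 log units; that floor lies within the scatter), involves a different exchange and offers little guidance. Going by the values given here, no measured step isolates butoxy, which among the measured compounds occurs only in compound 3 at 6830 nM. A moderate move toward a higher number in this assay is therefore expected.

The expected change is a 1.6-fold higher number from compound 3 to compound 4 (0.21 log units; within the scatter).

For compound 4 the estimated value is 11000 nM, with an expected range of 4500 nM to 25000 nM.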

Compound 4, half-maximal inhibitory concentration: > 20000 nM
Compound 4 was reported as a limit; the forecaster's own chance of this, stated with the estimate: 25%; middle value at least 1.8-fold (0.25 log units) from the limit.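

On the aromatic carbon para to a large group, butoxy cannot be cut back to methyl without loss in this assay: the exchange gives an at least 2.9-fold higher number from compound 3 to compound 4 (0.46 log units; beyond the scatter). Compound 4 is reported only as a limit of the assay, not a number: the limit of > 20000 nM in this assay, at which 2 of the 4 values shown sit. The comparison with the 2-chlorophenyl compound gives an at least 1.0-fold higher number from compound 2 to compound 4 (0.02 log units; that floor lies within the scatter), so it shows no clear difference, and the step between compound 1 and compound 4 cannot be read.

On these data alone, whether a longer chain than butoxy would lower the number further remains open. So does whether an ethoxy group or an amine at this carbon would keep the activity of compound 3.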